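The source may report more compounds than this note shows. Statements on the series, on what has been measured and on what is new or still open speak of the compounds shown alone.

In a functional assay on MGC-803 cells (Homo sapiens) for inhibition, read by MTT assay, with a stated time of 72 h (on this read-out higher numbers stand for weaker inhibition and lower numbers for stronger inhibition), the measured compounds are:

Compound 1 `Cc1cc(Nc2ccn(Cc3cccc4ccccc34)n2)n2nc(SCc3ccc(Br)cc3)nc2n1` gives 3240 nM.
Compound 2 `Cc1cc(Nc2cc(-c3ccccc3)[nH]n2)n2ncnc2n1` gives 21700 nM.
Compound 3 `Cc1cc(Nc2cc(-c3ccccc3)[nH]n2)n2nc(SCc3c(Cl)cccc3Cl)nc2n1` gives 5280 nM.

Compound 3 sits second highest of the three; its gap to compound 1 lies within the scatter, while compound 2 stands beyond it. Among the compounds with values here, the only single-point step, a 4.1-fold lower number from compound 2 to compound 3 (0.61 log units; beyond the scatter), shows that adding the (2,6-dichlorobenzyl)sulfanyl group lowers the number modestly. Compound 4 `Cc1cc(Nc2cc(-c3ccccc3)[nH]n2)n2nc(SCc3ccc(F)cc3)nc2n1` differs from compound 3 by 4-fluorophenyl in place of 2,6-dichlorophenyl on a saturated chain carbon bound to a sulfur. Within the data shown here, no measured step swaps one benzyl for another, so nothing here says how the aryl pattern matters. Compound 4 is therefore expected to stay near compound 3, with a 1.1-fold lower number from compound 3 to compound 4 (0.02 log units; within the scatter) not beyond the scatter. The estimate for compound 4 is 5000 nM, between 2000 nM and 13000 nM.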

Compound 4, half-maximal inhibitory concentration: 3270 nM
The estimate for compound 4 lay 1.5-fold (0.18 log units) above the measured number; low and high end bracket the measured number.
By their numbers in this assay, from the lowest: compounds 1, 4 and 3 (each within the scatter of the next); then compound 2.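

In this assay, exchanging 2,6-dichlorophenyl for 4-fluorophenyl on the saturated chain carbon bound to a sulfur gives a 1.6-fold lower number from compound 3 to compound 4 (0.21 log units; within the scatter), so the two aryl patterns cannot be told apart here. The second step, a 6.6-fold lower number from compound 2 to compound 4 (0.82 log units; beyond the scatter), shows that the drop seen with the (2,6-dichlorobenzyl)sulfanyl group in place of hydrogen also appears with (4-fluorobenzyl)sulfanyl. No supporting evidence accounts for this result. The compounds shown leave open whether the aromatic ring is needed at all: a methyl on the sulfur, or an amine at the end of a longer chain, remains untested here.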